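The source may report more compounds than this note shows. Statements on the series, on what has been measured and on what is new or still open speak of the compounds shown alone.

In an ADME assay on BHK cells (Mesocricetus auratus) for cytotoxicity, read by MTT assay, with a stated time of 96 h (on this read-out lower numbers stand for higher toxicity in this test and higher numbers for lower toxicity in this test), compound 1 `FC(F)(F)c1cccc(NC(=S)Nc2ccc(I)cc2)c1` gives 9400 nM. Compound 2 `CC(=O)NC(=S)Nc1cccc(C(F)(F)F)c1` gives > 100000 nM, which is a limit of the assay and not a number. The next compound, compound 3 `C=C(C)CNC(=S)Nc1cccc(C(F)(F)F)c1`, keeps the rest of compound 2 but carries 2-methylprop-2-en-1-yl in place of acetyl on an amide-type nitrogen. Within the data shown here, only one measured step bears on this change: an at least 10-fold higher number from compound 1 to compound 2 (1.02 log units; beyond the scatter), a large step beyond the scatter, in which acetyl replaced 4-iodophenyl at that same place. Compound 3 loses the acetyl again, so part of that step is expected to reverse, though probably not all of it, since the group entering is not 4-iodophenyl. The expected change is an at least 2.5-fold lower number from compound 2 to compound 3 (0.39 log units; beyond the scatter), towards lower numbers, which would mean higher toxicity in this test. For compound 3 the estimated value is 40000 nM, with an expected range from 12000 nM to 100000 nM.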

Compound 3, half-maximal cytotoxic concentration: > 100000 nM
Compound 3 ended at the assay's limit; the forecaster's own chance of this, stated with the estimate: 30%; middle value at least 2.5-fold (0.39 log units) from the limit.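

In this assay, 2-methylprop-2-en-1-yl in place of 4-iodophenyl on this amide-type nitrogen gives an at least 10-fold higher number from compound 1 to compound 3 (1.02 log units; beyond the scatter), so the higher number seen with acetyl does not require the carbonyl of that group. The step from acetyl to 2-methylprop-2-en-1-yl cannot be read, since compound 2 and compound 3 each stand at a limit of the assay and not at a number. Any difference between these two groups therefore stays hidden: the limit of > 100000 nM in this assay, at which 2 of the 3 values shown sit.

The compounds shown leave open whether the lower number of compound 1 goes with the aromatic ring itself or with its iodine, which a plain phenyl group on this nitrogen would help to separate. They also leave open whether a longer alkyl chain or a chain carrying an amine would bring the value back to a readable number.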